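The source may hold more compounds than are shown below. What is called first, only, known or untested is meant among the compounds shown, and "the series" means these compounds.

Of the compounds shown here, three built on a shared core have been tested in an ADME assay on MT4 cells (Homo sapiens) for cytotoxicity, read by MTT assay, with a stated time of 4 days; a higher number here means that more compound is tolerated, a lower number that less compound is tolerated. Compound 1 `C/C(=N\NC(=O)COc1cccc2ccccc12)c1ccc(O)cc1O` gives 59.9 ug/mL. Compound 2 `COc1ccc(/C=N/NC(=O)COc2cccc3ccccc23)cc1O` gives 7.05 ug/mL, and compound 3 `O=C(COc1cccc2ccccc12)N/N=C/c1ccc([N+](=O)[O-])cc1` gives 87.9 ug/mL. Of these three numbers, compound 1 stands second highest; its value and that of compound 3 lie within the scatter of each other, while compound 2 sits far lower, beyond the scatter. Compound 4 `C/C(=N\NC(=O)COc1cccc2ccccc12)c1ccccc1` has not yet been measured in this assay. It differs from compound 1 in one place: phenyl in place of 2,4-dihydroxyphenyl on a carbon with a double bond to nitrogen. Going by the values given here, no measured pair shows what this change does. The expected step is a 1.5-fold lower number from compound 1 to compound 4 (0.18 log units; within the scatter), small and probably toward a lower number, perhaps no larger than the scatter. Compound 4 is therefore estimated to give 40 ug/mL in this assay, within a range from 12 ug/mL to 120 ug/mL.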

Compound 4, half-maximal cytotoxic concentration: 105 ug/mL
Beside the measured number, compound 4's estimate is 2.6-fold (0.42 log units) below it, and the stated range covers the measured number.
By their numbers in this assay, from the lowest: compound 2; then compounds 1, 3 and 4 (each within the scatter of the next).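

Setting phenyl in place of 2,4-dihydroxyphenyl on a carbon with a double bond to nitrogen gives a 1.8-fold higher number from compound 1 to compound 4 (0.24 log units; within the scatter) in this assay. This first measured pair at this place shows that a phenyl with no hydrogen-bond donors or acceptors gives a number that cannot be told apart from that of the 2,4-dihydroxyphenyl compound. No measurement is available that would explain the result. From the compounds shown here alone, whether an amine or a carboxylic acid at this place would move the number beyond the scatter remains open.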